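Amine substitution on the carbocyclic ring of compound 1

The source may hold more compounds than are shown below. What is called first, only, known or untested is meant among the compounds shown, and "the series" means these compounds.

Compound 1 `CCCCCn1c(N)nc2ccccc21` is the reference point of the series. In an assay on HEK293 cells for agonist activity at Toll-like receptor 8 (Homo sapiens), read by reporter gene assay (a lower number here means that less compound is needed, a higher number that more compound is needed for the effect), compound 1 gives 3230 nM, the lowest of the two numbers recorded so far; its nearest neighbour is compound 3 `CCCCCn1c(N)nc2cccc(C)c21`, which gives 6610 nM in this assay. Within the data shown here, compound 2 `CCCCCn1c(N)nc2ccncc21` is reported in this assay as "not active" (no number reported), with no number attached, so it supports no step.

Compound 4 `CCCCCn1c(N)nc2c(N)cccc21` differs from compound 1 by amino in place of hydrogen on an aromatic carbon. Among the measured compounds shown here, the only measured step that bears on this change is the one from compound 1 to compound 3, where a methyl in place of hydrogen on an aromatic carbon of the same ring produced a 2.0-fold higher number from compound 1 to compound 3 (0.31 log units; beyond the scatter). For the measured compounds named here, that single step suggests that substitution of hydrogen on the carbocyclic ring of this core is tolerated but tends to push the number up modestly; no measured compound carries an amino group, and the position differs, so the comparison is loose.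

On this basis compound 4 is expected to give about 5000 nM in this assay, within a range of 2000 nM to 15000 nM. The change from compound 1 to compound 4 is therefore estimated at a 1.5-fold higher number from compound 1 to compound 4 (0.19 log units; within the scatter), a step of roughly the same size and direction as the one seen for the methyl analogue, and not confidently beyond the scatter.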

Compound 4, half-maximal effective concentration: 6600 nM
Beside the measured number, compound 4's estimate is 1.3-fold (0.12 log units) below it; low and high end bracket the measured number.
By their numbers in this assay, from the lowest: compound 1; then compounds 4 and 3 (each within the scatter of the next).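

Compound 4 shows that amino in place of hydrogen on this aromatic carbon leaves a measurable number in this assay, with a modest cost: a 2.0-fold higher number from compound 1 to compound 4 (0.31 log units; beyond the scatter). Together with a 2.0-fold higher number from compound 1 to compound 3 (0.31 log units; beyond the scatter), this gives two substitutions on the carbocyclic ring, with different groups on different carbons, and both steps run in the same direction, so neither group yields a number lower than that of the unsubstituted compound 1. Nothing shown accounts for the rise with amino, and no supporting measurement bears on it.

The shown compounds carry methyl and amino on different carbons, so they leave open whether the two steps reflect the group, the place or both; amino on the carbon bearing methyl in compound 3, and methyl on the carbon bearing amino in compound 4, would separate these. As far as these compounds go, it also remains open whether a hydroxyl, a methoxy or a dimethylamino group on the same carbon as in compound 4 would keep, raise or lower the number.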